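The source may report more compounds than this note shows. Statements on the series, on what has been measured and on what is new or still open speak of the compounds shown alone.

Measured in a functional assay on a cell-free system (plasma, Homo sapiens), with a stated time of 3 min; on this read-out lower numbers stand for stronger inhibition and higher numbers for weaker inhibition:
- Compound 1 `O=C(NCc1cc(Cl)ccc1-n1cnnn1)[C@@H]1C[C@@H]2C[C@@H]2N1C(=O)[C@H](O)CC1CC1`: 1700 nM
- Compound 2 `O=C(NCc1cc(Cl)ccc1-n1cnnn1)[C@@H]1C[C@@H]2C[C@@H]2N1C(=O)[C@H](O)c1cccc(Cl)c1`: 1000 nM
- Compound 3 `CC(C)(C)[C@@H](O)C(=O)N1C[C@@H]2C[C@@H]2[C@H]1C(=O)NCc1cc(Cl)ccc1-n1cnnn1`: 570 nM

Compound 1 and compound 3 each lie within the scatter of compound 2 at 1000 nM. The next compound, compound 4 `O=C(NCc1cc(Cl)ccc1-n1cnnn1)[C@@H]1C[C@@H]2C[C@@H]2N1C(=O)[C@H](O)C1CCCCC1`, carries cyclohexyl in place of 3-chlorophenyl on a saturated chain carbon bound to a carbonyl carbon and an oxygen on a saturated carbon. Going by the values given here, the only measured step at this place is a 1.7-fold lower number from compound 1 to compound 2 (0.23 log units; within the scatter), which exchanged cyclopropylmethyl for 3-chlorophenyl. No change beyond the scatter is therefore expected in this assay, and the expected step is a 1.3-fold lower number from compound 2 to compound 4 (0.10 log units; within the scatter). For compound 4 the estimated value is 800 nM, with an expected range from 300 nM to 2200 nM.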

Compound 4, half-maximal inhibitory concentration: 600 nM
The estimate for compound 4 lay 1.3-fold (0.12 log units) above the measured number; low and high end bracket the measured number.
By their numbers in this assay, from the lowest: compounds 3, 4, 2 and 1 (each within the scatter of the next, the first and the last beyond it).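

In this assay, cyclohexyl and 3-chlorophenyl on this saturated chain carbon cannot be told apart (a 1.7-fold lower number from compound 2 to compound 4 (0.22 log units; within the scatter)), so an aromatic ring and its chlorine are not required to reach this range. Cyclohexyl in place of cyclopropylmethyl does give a modest step beyond the scatter (a 2.8-fold lower number from compound 1 to compound 4 (0.45 log units; beyond the scatter)), the only such step at this position. No available evidence bears on either step. From the compounds shown here alone, whether an amine, a carboxylic acid or a longer chain on this carbon would fit the same range remains open.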